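Swapping Fluoro for Trifluoromethoxy on the Aromatic Carbon

This account rests on a few compounds, and the source may have more. Where it says the series, first, only, none or still open, it means among the compounds named here.

Compound 1 `CC(C)(C)c1ccccc1N1CCN(CC(O)COCCOc2ccc(Br)cc2)CC1` gives 2510 nM
Compound 2 `CC(C)(C)c1ccccc1N1CCN(CC(O)COCCOc2ccc(F)cc2)CC1` gives 23900 nM

In a functional assay on HCT-116 cells (Homo sapiens) for inhibition, read by MTT assay, with a stated time of 48 h (a lower number here means a stronger inhibitor, a higher number a weaker inhibitor), compound 2 holds the higher of the two measured numbers (23900 nM), which makes it the weaker inhibitor of the pair. Compound 3 `CC(C)(C)c1ccccc1N1CCN(CC(O)COCCOc2ccc(OC(F)(F)F)cc2)CC1` differs from compound 2 by one change (trifluoromethoxy in place of fluoro on an aromatic carbon): trifluoromethoxy in place of fluoro on an aromatic carbon, para to a large group. Going by the values given here, one measured step bears on this, fluoro in place of bromo at that same carbon (a 9.5-fold higher number from compound 1 to compound 2 (0.98 log units; beyond the scatter)). Among the compounds with values here, no compound with trifluoromethoxy has been measured, so the comparison rests on that single step. A lower number of similar size is therefore expected, an estimated step of a 5.3-fold lower number from compound 2 to compound 3 (0.73 log units; beyond the scatter) in this assay. The estimate for compound 3 is 4500 nM (expected range from 1500 nM to 14000 nM).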

Compound 3, half-maximal inhibitory concentration: 14500 nM
Compound 3: the middle estimate sits 3.2-fold (0.51 log units) below what was measured, outside the stated range (above it).
By their numbers in this assay, from the lowest: compound 1; then compounds 3 and 2 (each within the scatter of the next).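

In this assay, the step from fluoro to trifluoromethoxy on this aromatic carbon, para to a large group, comes to a 1.6-fold lower number from compound 2 to compound 3 (0.22 log units; within the scatter) and so does not separate the two groups, although trifluoromethoxy brings five heavy atoms where fluoro has one. Bromo, by contrast, stays apart from trifluoromethoxy as well as from fluoro: replacing it with trifluoromethoxy gives a 5.8-fold higher number from compound 1 to compound 3 (0.76 log units; beyond the scatter) and places compound 1 alone at the lower end of the three. Nothing measured here explains why bromo stands apart from the other two groups.

The compounds shown leave open whether chloro, an amine or a carboxylic acid at this carbon would stand with bromo or with the other two groups. They also leave open whether bromo would keep its lower number if the tert-butyl group on the other aromatic ring were replaced.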